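This account rests on a few compounds, and the source may have more. Where it says the series, first, only, none or still open, it means among the compounds named here.

Working notes on the series.

Compound 1 `COc1ccc(-c2[nH]c3ccccc3c2/C=C(\C#N)S(=O)(=O)c2ccccc2)cc1` stands in a functional assay on NCI-H226 cells (Homo sapiens) for inhibition, read by sulforhodamine B assay, with a stated time of 48 h (a higher number here means a weaker inhibitor of growth, a lower number a stronger inhibitor of growth), at 2800 nM, the lower of the two numbers in hand. Compound 2 `COc1ccc2[nH]c(-c3ccccc3)c(C=C(C#N)C#N)c2c1` gives 3500 nM in this assay; its value and that of compound 1 sit within the scatter of each other, so the two cannot be ranked.

The step under consideration goes to compound 3 `COc1ccc(-c2[nH]c3ccc(OC)cc3c2/C=C(\C#N)S(=O)(=O)c2ccccc2)cc1`, which differs from compound 1 by methoxy in place of hydrogen on an aromatic carbon of the shared core. Among the compounds with values here, no step between measured compounds isolates this change, and compound 2 shares only parts of the pattern, so there is no basis for a large shift in either direction. A step of no more than the usual scatter is expected, leaning slightly toward a lower number.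

Compound 3 is therefore estimated at 2300 nM, with a range of 900 nM to 6000 nM, which corresponds to an expected step of a 1.2-fold lower number from compound 1 to compound 3 (0.09 log units; within the scatter).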

Compound 3, concentration for 50% growth inhibition: 3700 nM
Beside the measured number, compound 3's estimate is 1.6-fold (0.21 log units) below it, and the stated range covers the measured number.
By their numbers in this assay, from the lowest: compounds 1, 2 and 3 (each within the scatter of the next).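

In this assay, within the data shown here, methoxy in place of hydrogen on an aromatic carbon of the shared core gives a 1.3-fold higher number from compound 1 to compound 3 (0.12 log units; within the scatter) and is the first step that isolates a single change. At this position, on a six-membered aromatic ring of carbon only that is part of a fused system, methoxy is tolerated without a shift that can be told from the scatter, so compound 1 and compound 3 cannot be ranked. No measured evidence bears on this result.

Still open, on these data alone, is whether an amine, a carboxylic acid or a longer alkoxy chain in place of methoxy at this position would give a step beyond the scatter. Also open, as far as these compounds go, is whether methoxy on the other aromatic carbons of this ring would give a step of similar size.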